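From Fluoro to Amino: An Expected Permeability Step

The source may report more compounds than this note shows. Statements on the series, on what has been measured and on what is new or still open speak of the compounds shown alone.

Measured compounds:
- compound 1, `Cc1cc(NC(=O)Nc2cc(F)ccc2F)c2ccccc2n1`, gives 541 10^-6 cm/s in an ADME assay for permeability, using PAMPA, at pH 7.4; a lower number here means that the compound crosses the layer more slowly, a higher number that the compound crosses the layer faster
- compound 2, `Cc1cc(NC(=O)Nc2ccccc2F)c2ccccc2n1`, gives 817 10^-6 cm/s
- compound 3, `Cc1cc(NC(=O)Nc2ccc(F)cc2F)c2ccccc2n1`, gives 640 10^-6 cm/s

The three numbers sit close together: a 1.5-fold higher number from compound 1 to compound 2 (0.18 log units; within the scatter) and a 1.3-fold lower number from compound 2 to compound 3 (0.11 log units; within the scatter), so compound 2 is not separated from either neighbour beyond the scatter. Compound 4, `Cc1cc(NC(=O)Nc2ccccc2N)c2ccccc2n1`, differs from compound 2 by amino in place of fluoro on an aromatic carbon, and the change brings in one hydrogen-bond donor and one hydrogen-bond acceptor where fluoro carried none. Both measured steps swap only hydrogen and fluoro, so none of them covers an amino group; they show merely that small changes at this ring left this assay flat. Among the compounds with values here, with no direct precedent, a modest drop is expected, a 1.8-fold lower number from compound 2 to compound 4 (0.26 log units; within the scatter). Compound 4 is therefore estimated at 450 10^-6 cm/s, between 200 10^-6 cm/s and 900 10^-6 cm/s.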

Compound 4, apparent permeability: 300 10^-6 cm/s
Estimate against measurement, compound 4: 1.5-fold (0.18 log units) above, within the range that was stated.
By their numbers in this assay, from the lowest: compounds 4, 1, 3 and 2 (each within the scatter of the next, the first and the last beyond it).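

The fluoro changed here is shared by compound 1, compound 2 and compound 3, so those compounds said nothing about this position. In this assay, amino in its place gives a 2.7-fold lower number from compound 2 to compound 4 (0.44 log units; beyond the scatter) and, unlike the two swaps of hydrogen and fluoro, this step lies beyond the scatter, so this ring does not stay flat under every change. Nothing shown here accounts for the step. As far as these compounds go, whether a hydroxyl or a methyl group in the same place would give a similar step stays open, as does the effect of a methylamino group.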